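Methylsulfanyl in place of propoxy on a tolerated core

The compounds below may be only part of what the source reports. "The series", "measured", "known", "first", "only" and "open" are said of these compounds alone.

Compound 1 `CCCOc1nc(N)nc2c1ncn2/C=C1/CC1(CO)CO` was examined in an ADME assay on HFF cells (Homo sapiens) for cytotoxicity, with a stated time of 8 days; a lower number here means that less compound is tolerated, a higher number that more compound is tolerated. In this assay compound 1 reaches only the limit of > 300000 nM. Two further compounds share its core. Compound 2 `Nc1nc(NCc2ccccc2)c2ncn(/C=C3/CC3(CO)CO)c2n1` gives in this assay the limit of > 300000 nM. Compound 3 `CCCSc1nc(N)nc2c1ncn2/C=C1/CC1(CO)CO` gives in this assay the limit of > 300000 nM. The steps among these three, a step that the two limits leave unreadable from compound 1 to compound 2, a step that the two limits leave unreadable from compound 1 to compound 3 and a step that the two limits leave unreadable from compound 2 to compound 3, are unreadable. Compound 1 thus stands at the same limit as every other measured compound, and this is because of the limit of > 300000 nM in this assay, at which 3 of the 3 values shown sit.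

Compound 4 `CSc1nc(N)nc2c1ncn2/C=C1/CC1(CO)CO` is the next variant: methylsulfanyl in place of propoxy on an aromatic carbon. The two steps that bear on it both alter the same aromatic carbon of compound 1 and leave no readable size; compound 3 carries propylsulfanyl, related to the methylsulfanyl entering in compound 4, and its value also sits at the limit. Nothing seen here points to a step beyond the scatter in this assay. Compound 4 is therefore expected to sit at 300000 nM, within 150000 nM to 600000 nM. Among the compounds with values here, the step this estimate implies, a number no higher from compound 1 to compound 4 (the limit leaves the size open), is expected to be essentially no step at all, most likely ending again at the limit of the assay.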

Compound 4, half-maximal cytotoxic concentration: > 300000 nM
Compound 4: a limit, no number; the forecaster's own chance of this, stated with the estimate: 85%; the middle value lies on the limit itself.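

No step linking compound 4 with compound 1, compound 2 or compound 3 can be read, because all four compounds stand at the same limit: the limit of > 300000 nM in this assay, at which 4 of the 4 values shown sit.

The compounds shown leave open how far apart these four lie in this assay, and which group on that aromatic carbon, if any, would give a number rather than a limit.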